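Benzyl substituent swap on the biphenyl-acid imidazole series

The compounds below may be only part of what the source reports. "The series", "measured", "known", "first", "only" and "open" are said of these compounds alone.

Of the compounds shown here, two carry numbers so far. Compound 1 `Cc1cccc(Cc2cnc(CCc3ccc(-c4ccccc4C(=O)O)cc3)[nH]2)c1` gives 75 nM in an in vitro functional assay on cells for agonist activity at Bombesin receptor subtype-3 (Mus musculus), read by luminescence and calcium flux; a higher number here means that more compound is needed for the effect, a lower number that less compound is needed. For the measured compounds named here, compound 2 `O=C(O)c1ccccc1-c1ccc(CCc2ncc(Cc3ccc(F)cc3)[nH]2)cc1` gives 50 nM in this assay; compound 2 stands alongside compound 1 as the only other measured member, and the step of a 1.5-fold lower number from compound 1 to compound 2 (0.18 log units; within the scatter) shows the two numbers sit inside the usual scatter. Compound 3 `N#Cc1ccccc1Cc1cnc(CCc2ccc(-c3ccccc3C(=O)O)cc2)[nH]1` is not yet measured. Its change from compound 2 is 2-cyanophenyl in place of 4-fluorophenyl on a saturated chain carbon bound to an aromatic carbon. Going by the values given here, the only step bearing on this place is a 1.5-fold lower number from compound 1 to compound 2 (0.18 log units; within the scatter), an exchange of one benzyl substituent for another that moved nothing beyond the scatter; the 2-cyanophenyl group has no precedent of its own. The expectation is therefore no step beyond the scatter in this assay, read as a 1.4-fold higher number from compound 2 to compound 3 (0.15 log units; within the scatter), with a wide range. Compound 3 is estimated at 70 nM, between 25 nM and 200 nM.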

Compound 3, half-maximal effective concentration: 642 nM
For compound 3 the middle estimate is 9.2-fold (0.96 log units) below the measured one; the measured number lies above the stated range.
By their numbers in this assay, from the lowest: compounds 2 and 1 (each within the scatter of the next); then compound 3.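

In this assay this place on the saturated chain carbon proves sensitive to the group it carries: 2-cyanophenyl in place of 4-fluorophenyl gives a 13-fold higher number from compound 2 to compound 3 (1.11 log units; beyond the scatter) and, set against 3-methylphenyl, it gives an 8.6-fold higher number from compound 1 to compound 3 (0.93 log units; beyond the scatter) even though the exchange of those two earlier groups stayed within the scatter. The series therefore does not accept every substituted benzyl equally, and the earlier step gave no sign of this. Nothing available explains the loss.

As far as these compounds go, it remains open whether the loss follows the nitrile itself or the way 2-cyanophenyl is substituted. An unsubstituted phenyl or a methoxyphenyl at this place would help show how far the effect extends beyond the three groups seen here.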